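Benzyl in place of 4-cyanophenyl on an amide-type nitrogen

The source may report more compounds than this note shows. Statements on the series, on what has been measured and on what is new or still open speak of the compounds shown alone.

Of the compounds shown here, three with a shared core have been measured in a functional assay on HepG2 cells (Homo sapiens) for inhibition, read by MTT assay, with a stated time of 72 h; a lower number here means a stronger inhibitor, a higher number a weaker inhibitor. Compound 1 (`CC(C)c1ccc(NC(=O)C2CCN(C/C=C/c3ccccc3)CC2)cc1`) gives 12200 nM, compound 2 (`COc1ccc(NC(=O)C2CCN(C/C=C/c3ccccc3)CC2)cc1`) gives 88800 nM, and compound 3 (`N#Cc1ccc(NC(=O)C2CCN(C/C=C/c3ccccc3)CC2)cc1`) gives 38300 nM. Compound 3 therefore holds the second highest of the three numbers, lying between the other two. The measured steps that reach it are a 3.1-fold higher number from compound 1 to compound 3 (0.50 log units; beyond the scatter) and a 2.3-fold lower number from compound 2 to compound 3 (0.37 log units; beyond the scatter). The remaining measured step is a 7.3-fold higher number from compound 1 to compound 2 (0.86 log units; beyond the scatter). All three are modest but beyond the scatter.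

The next compound, compound 4 (`O=C(NCc1ccccc1)C1CCN(C/C=C/c2ccccc2)CC1`), carries benzyl in place of 4-cyanophenyl on an amide-type nitrogen. For the measured compounds named here, none of the measured steps tests this change, since each only exchanges one group for another on an aromatic carbon. They offer only a rough guide to size, and the largest of them is a 7.3-fold higher number from compound 1 to compound 2 (0.86 log units; beyond the scatter). They give no basis for choosing a direction in this assay, so no step beyond the scatter is expected. The expected result is a 1.1-fold lower number from compound 3 to compound 4 (0.04 log units; within the scatter), with a wide margin of uncertainty. For compound 4 the estimated value is 35000 nM, with an expected range from 14000 nM to 90000 nM.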

Compound 4, half-maximal inhibitory concentration: > 100000 nM
Compound 4 gave a limit, no number; the forecaster's own chance of this, stated with the estimate: 15%; at least 2.8-fold (0.45 log units) between middle value and limit.
By their numbers in this assay, from the lowest: compound 1; then compound 3; then compound 2. At a limit, above all of these: compound 4.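

In this assay, compound 4 gives a limit, not a number: the limit of > 100000 nM in this assay, at which 1 of the 4 values shown sits. Until now only groups on an aromatic carbon had been exchanged, and this change shows that the group on the amide-type nitrogen also matters: benzyl in place of 4-cyanophenyl gives an at least 2.6-fold higher number from compound 3 to compound 4 (0.41 log units; beyond the scatter), and benzyl in place of 4-isopropylphenyl gives an at least 8.1-fold higher number from compound 1 to compound 4 (0.91 log units; beyond the scatter). Against 4-methoxyphenyl the same exchange gives an at least 1.1-fold higher number from compound 2 to compound 4 (0.05 log units; that floor lies within the scatter), which does not put compound 2 and compound 4 in order, although each of the three compounds with a substituted phenyl on that nitrogen gives a number and compound 4 does not.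

Compound 4 differs from the other three both in having a carbon that links the ring to the nitrogen and in lacking a substituent on the ring, and the compounds shown do not separate these two differences. They also leave open whether an unsubstituted phenyl, a 4-isopropylbenzyl or a 2-phenylethyl group on that nitrogen would give a number in this assay.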